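A few compounds are considered here, and "the series" means these few. Any claim that something is new, unique, unknown or untested is made for them only; others in the source may bear on it.

Compound 1 `CC1(C)c2[nH]nc(NC(=O)c3ccccc3)c2CN1Cc1cc(F)cc(F)c1` gives 190 nM in an assay on Sf21 cells for inhibition of high affinity nerve growth factor receptor (Homo sapiens), read by HTRF, with a stated time of 30 min, in the presence of a further agent that is not named here; a higher number here means a weaker inhibitor, a lower number a stronger inhibitor. Compound 2 `CC1(C)c2[nH]nc(NC(=O)c3ccccc3)c2CN1Cc1c(F)cccc1F` gives 520 nM in this assay, the higher of the two measured values; the step of a 2.7-fold higher number from compound 1 to compound 2 (0.44 log units; beyond the scatter) lies beyond the scatter. Compound 3 `CC1(C)c2[nH]nc(NC(=O)c3ccccc3)c2CN1Cc1cc(F)c(F)c(F)c1` has not yet been measured; it differs from compound 2 in one place: 3,4,5-trifluorophenyl in place of 2,6-difluorophenyl on a saturated chain carbon bound to an amine nitrogen in a ring. Among the measured compounds shown here, the only measured step that bears on this change is a 2.7-fold higher number from compound 1 to compound 2 (0.44 log units; beyond the scatter), in which shifting the fluorines around the same ring moved the number by a modest amount. Because compound 1 gave 190 nM with a fluorine pattern closer to that of compound 3, the step of a 2.3-fold lower number from compound 2 to compound 3 (0.35 log units; beyond the scatter) is expected to be a modest drop, toward the value of compound 1 rather than away from it. In this assay compound 3 is therefore estimated at 230 nM, with a likely range from 90 nM to 600 nM.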

Compound 3, half-maximal inhibitory concentration: 6960 nM
Beside the measured number, compound 3's estimate is 30-fold (1.48 log units) below it; the whole stated range lies below it.
By their numbers in this assay, from the lowest: compound 1; then compound 2; then compound 3.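

In this assay this position tolerates some changes in the fluorine pattern but not others: one extra fluoro in place of hydrogen on an aromatic carbon gives a 37-fold higher number from compound 1 to compound 3 (1.56 log units; beyond the scatter), far more than a 2.7-fold higher number from compound 1 to compound 2 (0.44 log units; beyond the scatter) seen when the two fluorines sit elsewhere on the ring. The change from 2,6-difluorophenyl to 3,4,5-trifluorophenyl gives a 13-fold higher number from compound 2 to compound 3 (1.13 log units; beyond the scatter), so among these three compounds a similar-looking fluorine pattern did not mean a similar number, and the single added fluoro outweighed the moved pair. Nothing available here explains this loss.

Still open, on these data alone, is whether only fluoro causes such a loss or whether a chloro, a methoxy or an amine in its place would do the same. As far as these compounds go, the value of the plain phenyl ring, with no fluoro at all, is also open.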